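This account rests on a few compounds, and the source may have more. Where it says the series, first, only, none or still open, it means among the compounds named here.

The set is small, and two of its three values are limits rather than numbers. In an ADME assay on J774.1 cells (Mus musculus) for cytotoxicity, read by resazurin assay, with a stated time of 48 h (on this read-out higher numbers stand for weaker inhibition and lower numbers for stronger inhibition), compound 1, `CCCn1cc(C(=O)NCc2ccccc2)c(=O)c2cc(F)c(N3CCC(C(N)=O)CC3)cc21`, gives 43700 nM. Compound 2, `CCn1cc(C(=O)O)c(=O)c2ccc(C(F)(F)F)cc21`, reaches only the limit of the assay, > 100000 nM, with no number behind it. Compound 3, `NC(=O)C1CCN(c2cc3c(cc2F)c(=O)c(C(=O)NCc2ccco2)cn3C2CC2)CC1`, likewise stops at the limit, > 100000 nM, so no number is known for it. On what is shown, compound 3 therefore stands with compound 2 at the limit of > 100000 nM in this assay, at which 2 of the 3 values shown sit, and the one measured number, that of compound 1, lies elsewhere.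

Compound 4, `COc1ccc(CNC(=O)c2cn(C3CC3)c3cc(N4CCC(C(N)=O)CC4)c(F)cc3c2=O)cc1`, has not yet been measured. It differs from compound 3 in one place: 4-methoxyphenyl in place of furan-2-yl on a saturated chain carbon bound to an amide-type nitrogen. Among the measured compounds shown here, no step between measured compounds tracks this change, and the starting point is itself a limit. Compound 4 is expected to show no step beyond the scatter, a number no higher from compound 3 to compound 4 (the limit leaves the size open), and so to remain at the limit. Compound 4 is estimated at 100000 nM, within 40000 nM to 300000 nM.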

Compound 4, half-maximal inhibitory concentration: > 100000 nM
Compound 4: only a limit was reported; the forecaster's own chance of this, stated with the estimate: 70%; the middle value lies on the limit itself.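

Compound 3 and compound 4 both end at a limit in this assay rather than at a number, so no step can be read between them. The compounds shown leave open whether 4-methoxyphenyl in place of furan-2-yl changes this read-out at all.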